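Replacing the Methyl on the Carbonyl Carbon of Compound 1

This account rests on a few compounds, and the source may have more. Where it says the series, first, only, none or still open, it means among the compounds named here.

Of the compounds shown here, three sharing one core have been measured in an assay on CHO cells for displacement of a labelled ligand from adenosine receptor A1 (Homo sapiens), tested at 10 uM; a lower number here means less inhibition, a higher number more inhibition at the concentration tested (going by the name of the read-out). Compound 1 `CC(=O)Nc1nn(-c2ccccc2)c(=O)c2ccccc12` carries a methyl on the carbonyl carbon and gives 52%, the highest of the three numbers. Compound 2 `O=C(Nc1nn(-c2ccccc2)c(=O)c2ccccc12)c1ccc(Cl)cc1` carries a 4-chlorophenyl there and gives 26%; compound 3 `O=C(NCc1ccccc1)Nc1nn(-c2ccccc2)c(=O)c2ccccc12` carries a benzylamino there and gives 20%. The step of a number 26 percentage points lower from compound 1 to compound 2 (beyond the scatter) and the step of a number 32 percentage points lower from compound 1 to compound 3 (beyond the scatter) both fall beyond the scatter, whereas a number 6 percentage points lower from compound 2 to compound 3 (within the scatter) lies within it.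

Compound 4 `Cc1ccccc1NC(=O)Nc1nn(-c2ccccc2)c(=O)c2ccccc12` differs from compound 1 in a single place: (2-methylphenyl)amino in place of methyl on a carbonyl carbon. Both measured steps that exchanged the methyl on the carbonyl carbon for a larger group, to compound 2 and to compound 3, lowered the read-out in this assay well beyond the scatter, and the change to compound 4 is of the same kind, nearest to the benzylamino of compound 3. Because compound 3 with its related group gave 20%, compound 4 is expected to show a drop of similar size, a number 30 percentage points lower from compound 1 to compound 4 (beyond the scatter). The estimate for compound 4 is 22%, within 5% to 40%.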

Compound 4, a percentage reported as inhibition, at one concentration (the size of the read-out at that concentration, not a potency): 20%
Compound 4: middle estimate off by 2 percentage points, on the high side, within the range that was stated.
By their numbers in this assay, from the lowest: compounds 3, 4 and 2 (each within the scatter of the next); then compound 1.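

In this assay, (2-methylphenyl)amino on the carbonyl carbon is a third replacement for the methyl that ends well below compound 1 (a number 32 percentage points lower from compound 1 to compound 4 (beyond the scatter)), so the loss now holds for every replacement shown. The read-out does not separate this group from the earlier ones: 2-methylphenyl in place of benzyl on the amide-type nitrogen gives (no change at the digits printed from compound 3 to compound 4 (within the scatter)), and the exchange for 4-chlorophenyl gives (a number 6 percentage points lower from compound 2 to compound 4 (within the scatter)). No supporting measurement is available to explain the loss or why these three replacements read alike.

The compounds shown leave open whether an ethyl, a methoxy or a plain amino on the carbonyl carbon would stay with compound 1 or fall with the others. They also leave open how an unsubstituted phenylamino would read.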